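Swapping one aromatic ring on the shared core

The source may report more compounds than this note shows. Statements on the series, on what has been measured and on what is new or still open speak of the compounds shown alone.

Of the compounds shown here, two have been measured in an in vitro assay on HEK385-7 cells for displacement of a labelled ligand from prostaglandin D2 receptor 2 (Homo sapiens); a higher number here means a weaker inhibitor, a lower number a stronger inhibitor. Compound 1 `O=C(O)Cc1sc(C(c2ccccc2)c2ccc(F)cc2)nc1-c1ccc(Cl)cc1` gives 17 nM. Compound 2 `O=C(O)Cc1sc(C(c2ccc(F)cc2)c2ccc(F)cc2)nc1-c1cccc(F)c1` gives 1.4 nM, the lower of the two numbers, and the gap to compound 1 lies beyond the usual scatter. Compound 3 `O=C(O)Cc1sc(C(c2ccc(F)cc2)c2ccc(F)cc2)nc1-c1cc(F)nc(F)c1` has not yet been measured; it differs from compound 2 by 2,6-difluoropyridin-4-yl in place of 3-fluorophenyl on an aromatic carbon. Going by the values given here, no measured pair shows a change of this kind, so its effect cannot be read from the data. The estimated step is a 3.6-fold higher number from compound 2 to compound 3 (0.55 log units; beyond the scatter), a modest move toward a higher number. Compound 3 is expected to give about 5 nM, most likely between 1.5 nM and 20 nM.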

Compound 3, half-maximal inhibitory concentration: 5.4 nM
Compound 3: the middle estimate sits 1.1-fold (0.03 log units) below what was measured; the range from low to high includes it.
By their numbers in this assay, from the lowest: compound 2; then compound 3; then compound 1.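

At this position, on the aromatic carbon next to the ring nitrogen, placing 2,6-difluoropyridin-4-yl in place of 3-fluorophenyl gives in this assay a 3.9-fold higher number from compound 2 to compound 3 (0.59 log units; beyond the scatter), a modest change. Compound 3 still gives 5.4 nM, so this position tolerates a ring with a ring nitrogen and an added fluorine without a large loss. Nothing measured here explains the step.

Going by these compounds, the ring nitrogen and the fluorine atoms changed together, and their separate contributions remain unknown. Also open, on these data alone, is how plain pyridin-4-yl, without fluorine, or a non-aromatic morpholine ring would behave here.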